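Amide substituent survey on the coumarin-derived series

A few compounds are considered here, and "the series" means these few. Any claim that something is new, unique, unknown or untested is made for them only; others in the source may bear on it.

Measured so far:
compound 1 `COc1cc2cc(C(=O)NCc3ccc(F)cc3)c(=O)oc2cc1OCCCOc1no[n+]([O-])c1S(=O)(=O)c1ccccc1` 370 nM
compound 2 `COc1cc2cc(C(=O)Nc3ccccc3)c(=O)oc2cc1OCCCOc1no[n+]([O-])c1S(=O)(=O)c1ccccc1` 740 nM

In a functional assay on MCF7 cells (Homo sapiens) for inhibition, read by MTT assay, with a stated time of 48 h (a lower number here means a stronger inhibitor, a higher number a weaker inhibitor), compound 1 gives 370 nM. Among the compounds with values here, compound 2, which carries a plain phenyl on the amide nitrogen, gives 740 nM in this assay; this is the higher of the two numbers available, the only neighbour being compound 1, and the step of a 2.0-fold higher number from compound 1 to compound 2 (0.30 log units; within the scatter) stays within the scatter.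

Compound 3 `COc1cc2cc(C(=O)NCCCc3ccc(F)cc3)c(=O)oc2cc1OCCCOc1no[n+]([O-])c1S(=O)(=O)c1ccccc1` is not yet measured. It differs from compound 2 by 3-(4-fluorophenyl)propyl in place of phenyl on an amide-type nitrogen. Within the data shown here, the only measured step that bears on this position is a 2.0-fold higher number from compound 1 to compound 2 (0.30 log units; within the scatter), which shows that exchanging a 4-fluorobenzyl for a phenyl on the amide nitrogen moved the number only within the scatter. Compound 3 carries a 4-fluorophenyl group again, now on a three-carbon chain, so a result in the same region as compounds 1 and 2 is expected, with no step beyond the scatter in either direction.

Compound 3 is therefore estimated at 450 nM in this assay, within a range of 150 nM to 1400 nM. The expected step is a 1.6-fold lower number from compound 2 to compound 3 (0.22 log units; within the scatter).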

Compound 3, half-maximal inhibitory concentration: 600 nM
Compound 3: the middle estimate sits 1.3-fold (0.12 log units) below what was measured; the measured number falls inside the stated range.
By their numbers in this assay, from the lowest: compounds 1, 3 and 2 (each within the scatter of the next).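

In this assay, the amide nitrogen now carries an aryl group on a chain as well as directly or through a single carbon, and the number stays inside the scatter: a 1.2-fold lower number from compound 2 to compound 3 (0.09 log units; within the scatter). Extending the 4-fluorobenzyl of compound 1 to the 3-(4-fluorophenyl)propyl of compound 3 gives the same reading, a 1.6-fold higher number from compound 1 to compound 3 (0.21 log units; within the scatter), so across the three substituents shown neither the phenyl exchange nor the added chain length separates the compounds in this assay. No supporting data bear on why this position is so flat here.

The compounds shown hold no pair that differs only in the fluorine, so its contribution at this position stays open, as does any effect of a 4-chlorophenyl or a 4-methoxyphenyl group in its place. Also open, on these data alone, is whether an amine or a carboxylic acid on the amide substituent, or a chain longer than the 3-(4-fluorophenyl)propyl, would produce a step beyond the scatter.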